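Replacing a Phenoxypropyl Ether with a Phenyl Carbamate

The compounds below may be only part of what the source reports. "The series", "measured", "known", "first", "only" and "open" are said of these compounds alone.

Measured compounds:
- Compound 1, `COc1ccc(OCCCOc2cc(=O)n(CCCO)c3c2CC(C/C=C(\C)CCC=C(C)C)C(C)(C)C3)cc1`, gives 0% in a functional assay on PANC-1 cells (Homo sapiens) for inhibition, read by MTT assay, with a stated time of 24 h, tested at 10 uM; on this read-out higher numbers stand for more inhibition at the one concentration tested (going by the name of the read-out) and lower numbers for less inhibition.
- Compound 2, `CC(C)=CCC/C(C)=C/CC1Cc2c(OCCCOc3ccc(Cl)cc3)cc(=O)n(CCCO)c2CC1(C)C`, gives 0% in this assay.

Going by the values given here, compound 2 stands level with compound 1: the only measured step, no change at the digits printed from compound 1 to compound 2 (within the scatter), shows that swapping the substituent on the aromatic ring of the side chain leaves the read-out unchanged, and both compounds sit at the floor of the scale.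

Compound 3, `COc1cccc(NC(=O)Oc2cc(=O)n(CCCO)c3c2CC(C/C=C(\C)CCC=C(C)C)C(C)(C)C3)c1`, has not been measured. It differs from compound 2 in one place: (3-methoxyphenyl)carbamoyl in place of 3-(4-chlorophenoxy)propyl on an oxygen on an aromatic ring. This is a larger change than the one measured so far, since it exchanges the whole side chain rather than one substituent on it, so the step from compound 1 to compound 2 bears on it only loosely. Among the compounds with values here, with both measured compounds at the floor of the scale and no step showing any movement in this assay, there is no basis to expect a rise.

Compound 3 is therefore estimated to give about 5% in this assay, within 0% to 25%, a step of a number 5 percentage points higher from compound 2 to compound 3 (within the scatter) that is expected to stay within the scatter.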

Compound 3, a percentage reported as inhibition, at one concentration (the size of the read-out at that concentration, not a potency): 11.3%
Beside the measured number, compound 3's estimate is 6.3 percentage points below it; the range from low to high includes it.
By their numbers in this assay, from the lowest: compounds 1 and 2 (each within the scatter of the next); then compound 3.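

In this assay, going by these compounds alone, the oxygen on the aromatic ring is the first place where a change lifts the read-out off zero. Putting (3-methoxyphenyl)carbamoyl on this oxygen in place of 3-(4-chlorophenoxy)propyl gives a number 11.3 percentage points higher from compound 2 to compound 3 (beyond the scatter), and putting it in place of 3-(4-methoxyphenoxy)propyl gives a number 11.3 percentage points higher from compound 1 to compound 3 (beyond the scatter), so this position responds to an exchange of the whole group, whereas the earlier swap of chloro for methoxy on the aromatic ring gave no visible movement. The entering group has the same heavy-atom count as the group it replaces but adds a nitrogen and a hydrogen-bond donor, and nothing available explains why the number rises.

The exchange changes the link and the ring substituent together, so it remains unclear whether the rise comes from the carbamoyl link or from the 3-methoxy group on its ring. A (4-chlorophenyl)carbamoyl group on the same oxygen would help to separate the two, while an aminoalkyl chain there would show whether a basic amine can take the read-out further at this single concentration.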